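The compounds below may be only part of what the source reports. "The series", "measured", "known", "first", "only" and "open" are said of these compounds alone.

In a functional assay on PC-3 cells (Homo sapiens) for antiproliferative activity (a lower number here means a stronger inhibitor of growth, a higher number a weaker inhibitor of growth), compound 1 `COc1cc(-n2cc(-c3ccc(Cl)cc3)[nH]c2=O)cc(OC)c1OC` gives 15800 nM, the lower of the two numbers recorded. Compound 2 `COc1ccc(-c2cn(-c3ccc(Cl)cc3)c(=S)[nH]2)cc1OC` gives 63100 nM in this assay, a gap that lies beyond the usual scatter. Compound 3 `COc1cc(-n2cc(-c3ccccc3)[nH]c2=O)cc(OC)c1OC` differs from compound 1 by a single change: hydrogen in place of chloro on an aromatic carbon. Among the compounds with values here, no measured pair isolates this change, so its effect can only be expected, not read off. The expectation is a modest loss, and compound 3 is estimated to give 30000 nM in this assay, within a range of 10000 nM to 100000 nM. The step so expected, a 1.9-fold higher number from compound 1 to compound 3 (0.28 log units; within the scatter), is estimated to be small.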

Compound 3, concentration for 50% growth inhibition: 39800 nM
Compound 3: the middle estimate sits 1.3-fold (0.12 log units) below what was measured; low and high end bracket the measured number.
By their numbers in this assay, from the lowest: compound 1; then compounds 3 and 2 (each within the scatter of the next).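

In this assay, within the data shown here, going from 4-chlorophenyl to phenyl brings a 2.5-fold higher number from compound 1 to compound 3 (0.40 log units; beyond the scatter), the first change that is isolated in a single place. It shows that the chloro on this aromatic carbon, para to a large group, makes a measurable difference to growth inhibition on the core of compound 1. Nothing available explains this step. The compounds shown leave open how fluoro, an amine or a carboxylic acid would compare with chloro at this position. They also leave open whether the step would hold on another core.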